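Solubility notes: aryl replacement on the shared core

A few compounds are considered here, and "the series" means these few. Any claim that something is new, unique, unknown or untested is made for them only; others in the source may bear on it.

Measured so far:
compound 1 `Cc1cc(C)c(-c2nc3ccccc3[nH]2)cc1NC(=O)c1ccc(OCc2ccccn2)cc1` — in a physicochemical assay for solubility, at pH 7.4 (a lower number here means a less soluble compound, a higher number a more soluble compound), compound 1 gives < 1000 nM, a limit of the assay and not a number.
compound 2 `Cc1cc(C)c(-c2c(C)nn(C)c2C)cc1NC(=O)c1ccc(OCc2ccccn2)cc1` — in this assay compound 2 gives 35000 nM.
compound 3 `Cc1cc(C)c(-c2ccccn2)cc1NC(=O)c1ccc(OCc2ccccn2)cc1` — not yet measured in this assay.

Compound 2 holds the only number shown in this assay; the other value is a limit (the limit of < 1000 nM in this assay, at which 1 of the 2 values shown sits), so compound 2 cannot be placed against a second number.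

The step to compound 3 changes the aryl group on the shared core: pyridin-2-yl in place of 1,3,5-trimethyl-1H-pyrazol-4-yl on an aromatic carbon. Among the compounds with values here, one measured step bears on this place: an at least 35-fold higher number from compound 1 to compound 2 (1.54 log units; beyond the scatter), which took the value from a limit to a number when the two-ring aromatic group was replaced by the trimethylpyrazolyl. Within the data shown here, the change to compound 3 removes that trimethylpyrazolyl again for a single unsubstituted six-membered aromatic ring, the opposite direction of the one measured step; a decrease is therefore expected, smaller than that step since compound 3 does not carry the group of compound 1.

Expected: a 5.8-fold lower number from compound 2 to compound 3 (0.77 log units; beyond the scatter). For compound 3 the estimate in this assay is 6000 nM, range 1500 nM to 20000 nM.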

Compound 3, solubility: < 1000 nM
Compound 3 was reported as a limit (the forecaster's own chance of this, stated with the estimate: 20%); at least 6.0-fold (0.77 log units) between middle value and limit.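

In this assay, the change of aryl group gives an at least 35-fold lower number from compound 2 to compound 3 (1.54 log units; beyond the scatter), so compound 2 now stands apart from two different replacements on this aromatic carbon: the 1H-benzimidazol-2-yl of compound 1 and the pyridin-2-yl of compound 3. Compound 3 gives < 1000 nM, which is a limit of the assay and not a number. The low reading is therefore not confined to the two-ring group of compound 1, but the step from compound 1 to compound 3 cannot be read, and those two compounds cannot be ordered: the limit of < 1000 nM in this assay, at which 2 of the 3 values shown sit.

Going by these compounds, it remains open whether the number for compound 2 goes with the five-membered aromatic ring itself or with its methyl groups, a question that a pyrazol-4-yl without methyl groups would bear on. Also open, on these data alone, is how a pyridin-2-yl carrying methyl groups, or one carrying an amine such as morpholine, would read in this assay against compound 3.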